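This account rests on a few compounds, and the source may have more. Where it says the series, first, only, none or still open, it means among the compounds named here.

Measured compounds:
compound 1 `CN(C[C@H]1Cc2c(cccc2N2C[C@H]3CNC[C@H]3C2)CN1)[C@H]1CCCc2cccnc21` — 10.3 nM
compound 2 `CN1CCN(Nc2cccc3c2C[C@@H](CN(C)[C@H]2CCCc4cccnc42)NC3)CC1` — 47.4 nM

In a functional assay on CCRF-CEM cells for antagonist activity at C-X-C chemokine receptor type 4 (Homo sapiens), read by calcium flux, with stated times of 25 min and 90 s (on this read-out lower numbers stand for stronger inhibition and higher numbers for weaker inhibition), compound 1 gives the lower of the two numbers, and compound 2, which carries a different amine on the same aromatic position of the shared core, gives the higher one; the gap between them is beyond the usual scatter. Compound 3 `CN(C)C1CCN(c2cccc3c2C[C@H](CN(C)[C@H]2CCCc4cccnc42)NC3)CC1` has not yet been measured in this assay. It differs from compound 1 in one place: a group of 9 heavy atoms (7 carbon, 2 nitrogen; one six-membered non-aromatic ring with 1 hetero atom) in place of a group of 8 heavy atoms (6 carbon, 2 nitrogen; 2 five-membered non-aromatic rings with 1 hetero atom each), on an aromatic carbon. The group that leaves carries the only hydrogen-bond donor of that region, while the group that enters carries none, and both keep two hydrogen-bond acceptors. Going by the values given here, with no measured pair showing this kind of swap, the direction is uncertain; a modest move toward a higher number, close to the edge of the scatter, is expected, a 2.1-fold higher number from compound 1 to compound 3 (0.33 log units; beyond the scatter). Compound 3 is therefore estimated at 22 nM, with a range of 7 nM to 70 nM.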

Compound 3, half-maximal inhibitory concentration: 35.9 nM
Beside the measured number, compound 3's estimate is 1.6-fold (0.21 log units) below it; low and high end bracket the measured number.
By their numbers in this assay, from the lowest: compound 1; then compounds 3 and 2 (each within the scatter of the next).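

At this aromatic carbon, the shared core does not accept every amine equally in this assay: 4-(dimethylamino)piperidin-1-yl in place of the fused bicyclic group of compound 1 gives a 3.5-fold higher number from compound 1 to compound 3 (0.54 log units; beyond the scatter), a modest step. The change combines several differences, with the hydrogen-bond donor lost and two five-membered rings replaced by one six-membered ring, and this single step cannot separate them. Nothing available bears on the cause of the step.

The compounds shown leave open whether the hydrogen-bond donor or the ring system accounts for the step, and 4-aminopiperidin-1-yl on the same carbon would help separate the two. They also leave open whether an amine is needed at this position at all, a question that a methoxy group there would test.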